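Removing One Methoxy Group from Two Triazolyl Urea Cores

A few compounds are considered here, and "the series" means these few. Any claim that something is new, unique, unknown or untested is made for them only; others in the source may bear on it.

Measured compounds in a functional assay on MDA-MB-231 cells (Homo sapiens) for cytotoxicity, read by MTT assay, with a stated time of 48 h; a higher number here means a weaker inhibitor, a lower number a stronger inhibitor:
- compound 1, `COc1cc(CN(C(=O)Nc2cc(C(F)(F)F)cc(C(F)(F)F)c2)n2cnnc2)cc(OC)c1OC`, giving 24900 nM
- compound 2, `CCc1ccc(NC(=O)N(Cc2cc(OC)c(OC)c(OC)c2)n2cnnc2)cc1`, giving 24800 nM
- compound 3, `COc1ccc(CN(C(=O)Nc2cc(C(F)(F)F)cc(C(F)(F)F)c2)n2cnnc2)cc1OC`, giving 25300 nM

All three numbers sit close together. Compound 1 and compound 3 share the same core and differ in a single place: the change is hydrogen in place of methoxy on an aromatic carbon. The step it made, a 1.0-fold higher number from compound 1 to compound 3 (0.01 log units; within the scatter), shows that taking away this methoxy group left the result essentially unchanged in this pair.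

Compound 2 has a different core from compound 1; how the two cores differ is not broken down here. Compound 4, with structure `CCc1ccc(NC(=O)N(Cc2ccc(OC)c(OC)c2)n2cnnc2)cc1`, has not yet been measured. It stands to compound 2 as compound 3 stands to compound 1: the change is hydrogen in place of methoxy on an aromatic carbon, and the surroundings of the place are described in the same words for both pairs, so this is the same change made on the second core.

Among the measured compounds shown here, with only one earlier example of this change, the expectation for compound 4 rests on that single step. The step from compound 2 to compound 4 is expected to be a 1.0-fold higher number from compound 2 to compound 4 (0.00 log units; within the scatter), because the matching step a 1.0-fold higher number from compound 1 to compound 3 (0.01 log units; within the scatter) was within the scatter. Compound 4 is therefore estimated at 25000 nM, most likely falling between 12000 nM and 50000 nM.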

Compound 4, half-maximal inhibitory concentration: > 50000 nM
Compound 4 gave a limit, no number (the forecaster's own chance of this, stated with the estimate: 10%); at least 2.0-fold (0.30 log units) between middle value and limit.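

In this assay compound 4 gave > 50000 nM, which is a limit of the assay and not a number. Taking away the same methoxy group on the second core gave an at least 2.0-fold higher number from compound 2 to compound 4 (0.30 log units; that floor lies within the scatter), so the true size of this step could be as small as the one on the first core, or it could be much larger. The result therefore shows neither that the change carries over unchanged from one core to the other nor that it behaves differently on the second core, and the comparison stays unsettled: the same change on two cores in this assay, a 1.0-fold higher number (0.01 log units; within the scatter) from compound 1 to compound 3 and an at least 2.0-fold higher number (0.30 log units; that floor lies within the scatter) from compound 2 to compound 4; the limit leaves it open whether they differ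

One open question is how far the true value of compound 4 lies past the point where the assay stops giving numbers, which a limit cannot answer: the limit of > 50000 nM in this assay, at which 1 of the 4 values shown sits. The compounds shown also leave open what happens on either core when this methoxy group is replaced by something other than hydrogen, such as a hydroxyl group, a fluorine atom or a longer chain like ethoxy, so a second measured pair with a real number at both ends would be needed before any rule about this change could be stated.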